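A Hydroxy on the Bridge of Compound 1

The compounds below may be only part of what the source reports. "The series", "measured", "known", "first", "only" and "open" are said of these compounds alone.

Within the data shown here, compound 1 `c1ccc(CCc2ccccc2-c2c[nH]nn2)cc1` is one of two compounds measured in an assay on cells for inhibition of Indoleamine 2,3-dioxygenase 2 (Mus musculus), with a stated time of 24 h, tested at 200 uM; a higher number here means more inhibition at the concentration tested (going by the name of the read-out), a lower number less inhibition; there compound 1 gives 90%, and the only other number comes from compound 2 `Clc1ccc(CCc2ccccc2)c(-c2c[nH]nn2)c1`, which gives 97%. Among the measured compounds shown here, the one measured step, a number 7 percentage points higher from compound 1 to compound 2 (within the scatter), concerns chloro on an aromatic carbon and does not touch the chain. Compound 3 `OC(Cc1ccccc1-c1c[nH]nn1)c1ccccc1` differs from compound 1 by hydroxy in place of hydrogen on a saturated chain carbon bound to an aromatic carbon and a saturated chain carbon. For the measured compounds named here, no measured step bears on this change, so compound 3 is expected to show a number 2 percentage points lower from compound 1 to compound 3 (within the scatter), nothing beyond the scatter. Compound 3 is therefore estimated at 88%, between 70% and 98%.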

Compound 3, a percentage reported as inhibition, at one concentration (the size of the read-out at that concentration, not a potency): 47%
Compound 3: the middle estimate sits 41 percentage points above what was measured; the whole stated range lies above it.
By their numbers in this assay, from the lowest: compound 3; then compounds 1 and 2 (each within the scatter of the next).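

On the saturated chain carbon bound to an aromatic carbon and a saturated chain carbon, hydroxy in place of hydrogen gives a number 43 percentage points lower from compound 1 to compound 3 (beyond the scatter) in this assay. The chain is thus the first place shown where a change moves this read-out beyond the scatter, and the number is lower with hydroxy at this place than with hydrogen. Nothing at hand explains the loss. 

Going by these compounds, whether it belongs to hydroxy itself or would also follow from methoxy, fluoro or an amine on this carbon stays open. So does whether hydroxy on the other saturated chain carbon would give the same result.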